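A few compounds are considered here, and "the series" means these few. Any claim that something is new, unique, unknown or untested is made for them only; others in the source may bear on it.

Measured so far in a functional assay on MDA-MB-231 cells (Homo sapiens) for cytotoxicity, read by MTT assay, with a stated time of 48 h; a lower number here means a stronger inhibitor, a higher number a weaker inhibitor:

Compound 1 `O=C(/C=C/c1ccc2c(c1)B(O)OC2)c1ccc(-c2ccccc2)cc1`; compound 1 gives 6400 nM.
Compound 2 `O=C(/C=C/c1ccc2c(c1)B(O)OC2)c1ccc(Br)cc1`; compound 2 gives 9500 nM.
Compound 3 `CSc1ccc(C(=O)/C=C/c2ccc3c(c2)B(O)OC3)cc1`; compound 3 gives 9800 nM.

Compound 2 stands second highest of the three numbers. Its nearest neighbour is compound 3, a 1.0-fold higher number from compound 2 to compound 3 (0.01 log units; within the scatter); its furthest is compound 1, a 1.5-fold higher number from compound 1 to compound 2 (0.17 log units; within the scatter). Both lie within the scatter, so no order among the three compounds is established.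

Compound 4 `Nc1cccc(C(=O)/C=C/c2ccc3c(c2)B(O)OC3)c1` is not yet measured. It differs from compound 2 as follows: 3-aminophenyl in place of 4-bromophenyl on a carbonyl carbon. The measured steps each swap a single group on an aromatic carbon of the same aryl ring: a 1.5-fold higher number from compound 1 to compound 2 (0.17 log units; within the scatter), a 1.5-fold higher number from compound 1 to compound 3 (0.19 log units; within the scatter) and a 1.0-fold higher number from compound 2 to compound 3 (0.01 log units; within the scatter), all within the scatter. None of them exchanges the whole aryl group on the carbonyl carbon, and none brings in a hydrogen-bond donor, so they bear on the step to compound 4 only loosely, though they show that the series has so far been indifferent to such swaps. The step of a 1.1-fold lower number from compound 2 to compound 4 (0.02 log units; within the scatter) is therefore expected to stay within the scatter, with wide uncertainty. For compound 4 in this assay the estimate is 9000 nM, with a range from 3000 nM to 30000 nM.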

Compound 4, half-maximal inhibitory concentration: 3200 nM
For compound 4 the middle estimate is 2.8-fold (0.45 log units) above the measured one, and the stated range covers the measured number.
By their numbers in this assay, from the lowest: compounds 4, 1, 2 and 3 (each within the scatter of the next, the first and the last beyond it).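

In this assay, for the compounds shown here, the exchange of the whole aryl group on the carbonyl carbon gives the first step beyond the scatter (a 3.0-fold lower number from compound 2 to compound 4 (0.47 log units; beyond the scatter)), and the step is modest; the earlier swaps of a single group on the aryl ring all stayed within it. The entering 3-aminophenyl brings a hydrogen-bond donor at an unchanged heavy-atom count, but the names of the two groups differ in both the substituent and its ring position, so this one step does not separate those two changes. No measurement on hand accounts for the step.

Left open is how 4-aminophenyl and 3-bromophenyl on the same carbonyl carbon would compare with compound 4. Also open, on these data alone, is whether a hydroxyl, an acetamide or a carboxylic acid on that ring would give a similar number.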